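Working notes: the methyl to ethyl step

The compounds below may be only part of what the source reports. "The series", "measured", "known", "first", "only" and "open" are said of these compounds alone.

Values in an ADME assay on microsomes from liver (Rattus norvegicus) for metabolic stability (a lower number here means slower removal, a higher number faster removal of the compound), are as follows:
- compound 1 `Cn1c(=O)n(-c2cc(-c3ccc(F)cc3F)nc3[nH]ccc23)c2ccncc21` gives 272 mL/min/kg
- compound 2 `Cn1c(=O)n(-c2cc(-c3cc(Cl)ccc3F)nc3[nH]ccc23)c2ccncc21` gives 204 mL/min/kg
- compound 3 `Cc1cnc(-c2cc(Cl)ccc2F)cc1-n1c(=O)n(C)c2cnccc21` gives 105 mL/min/kg

Compound 3 holds the lowest of the three numbers, within the scatter of compound 2 and beyond the scatter of compound 1. Compound 4 `CCn1c(=O)n(-c2cc(-c3cc(Cl)ccc3F)ncc2C)c2ccncc21` differs from compound 3 by methyl in place of hydrogen on a saturated chain carbon bound to an aromatic nitrogen (methyl to ethyl). Among the compounds with values here, the one measured step of a 1.3-fold lower number from compound 1 to compound 2 (0.12 log units; within the scatter) concerns another group and stays within the scatter, and no measured step covers this change. Hence no step beyond the scatter is expected in this assay and the estimated step of a 1.2-fold higher number from compound 3 to compound 4 (0.08 log units; within the scatter) is small. Compound 4 is estimated at 125 mL/min/kg with an expected range from 65 mL/min/kg to 230 mL/min/kg in this series.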

Compound 4, clearance: 110 mL/min/kg
Beside the measured number, compound 4's estimate is 1.1-fold (0.06 log units) above it; the range from low to high includes it.
By their numbers in this assay, from the lowest: compounds 3, 4, 2 and 1 (each within the scatter of the next, the first and the last beyond it).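

In this assay, within the data shown here, the methyl to ethyl change on a saturated chain carbon bound to an aromatic nitrogen gives a 1.0-fold higher number from compound 3 to compound 4 (0.02 log units; within the scatter), the only measured step at this position. On the core of compound 3, this position therefore accepts the ethyl group with the number staying within the scatter. No available data give a reason for this result.

Going by these compounds, whether a longer chain such as propyl, or a chain ending in an amine or a carboxylic acid, would also stay within the scatter remains open. Also open, on these data alone, is whether methyl to ethyl reads the same on the core of compound 2.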